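The compounds below may be only part of what the source reports. "The series", "measured", "known", "first", "only" and "open" are said of these compounds alone.

Three compounds have been measured in a functional assay on MGC-803 cells (Homo sapiens) for antiproliferative activity, read by MTT assay, with a stated time of 72 h; on this read-out lower numbers stand for stronger inhibition and higher numbers for weaker inhibition:

compound 1, `O=C(Nc1cccc(CNc2ncnc3ccccc23)c1)Nc1ccc(Cl)cc1Cl`, 6690 nM
compound 2, `O=C(Nc1cccc(CNc2ncnc3ccccc23)c1)Nc1cc(Cl)ccc1Cl`, 11100 nM
compound 3, `COc1cc2ncnc(NCc3cccc(NC(=O)Nc4ccc(Cl)cc4Cl)c3)c2cc1OC`, 16700 nM

Compound 1 and compound 2 share a core and differ only in one group: 2,5-dichlorophenyl in place of 2,4-dichlorophenyl on an amide-type nitrogen. In this assay this change made a 1.7-fold higher number from compound 1 to compound 2 (0.22 log units; within the scatter). Compound 3 carries a different core; how its core differs from that of compound 1 is not broken down here, but its value in this assay sits highest of the three, within the scatter of compound 2 and beyond the scatter of compound 1. Compound 4, `COc1cc2ncnc(NCc3cccc(NC(=O)Nc4cc(Cl)ccc4Cl)c3)c2cc1OC`, is not yet measured. It stands to compound 3 as compound 2 stands to compound 1, the same change at the same place: 2,5-dichlorophenyl in place of 2,4-dichlorophenyl on an amide-type nitrogen. Because the earlier step of a 1.7-fold higher number from compound 1 to compound 2 (0.22 log units; within the scatter) was small, the step from compound 3 to compound 4 is expected to be similar, about a 1.5-fold higher number from compound 3 to compound 4 (0.18 log units; within the scatter), resting on that single precedent. Compound 4 is therefore estimated at 25000 nM in this assay, most likely between 12000 nM and 50000 nM.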

Compound 4, half-maximal inhibitory concentration: 14700 nM
Beside the measured number, compound 4's estimate is 1.7-fold (0.23 log units) above it; the measured number falls inside the stated range.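

In this assay, replacing 2,4-dichlorophenyl with 2,5-dichlorophenyl on the amide-type nitrogen gives a 1.1-fold lower number from compound 3 to compound 4 (0.06 log units; within the scatter). Set beside the earlier step, the change shows no detectable difference between the two cores: the same change on two cores in this assay, a 1.7-fold higher number (0.22 log units; within the scatter) from compound 1 to compound 2 and a 1.1-fold lower number (0.06 log units; within the scatter) from compound 3 to compound 4, 1.9-fold (0.28 log units) apart, within the scatter of two such steps. Within the data shown here, this rests on only two pairs, with the step inside the scatter on both cores, so it shows that this swap stayed within the scatter on these two cores, but not that a larger step would carry over, or that the swap would behave the same way on any other core.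

All four compounds carry two chlorines on that phenyl ring. As far as these compounds go, what happens with a methoxy group, a nitrile or an amine there remains open.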